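Epoxide in place of vinylsulfone on a bis(trifluoromethyl)phenyl core

The compounds below may be only part of what the source reports. "The series", "measured", "known", "first", "only" and "open" are said of these compounds alone.

Measured so far:
compound 1, `C=CC(=O)Nc1cc(C(F)(F)F)cc(C(F)(F)F)c1`, 0.8 h
compound 2, `C=CS(=O)(=O)c1cc(C(F)(F)F)cc(C(F)(F)F)c1`, < 0.017 h
compound 3, `O=C(CBr)c1cc(C(F)(F)F)cc(C(F)(F)F)c1`, < 0.017 h

In an ADME assay for pharmacokinetics, read by LC-MS, in phosphate buffer, with a stated time of 72 h, at pH 7.4, tested at 250 uM (a higher number here means that the compound lasts longer, a lower number that the compound disappears faster), compound 1 gives 0.8 h. For compound 2 the value < 0.017 h is a limit of the assay, not a number. For compound 3 the value < 0.017 h is likewise a limit. Compound 2 thus stands at the floor of what was shown, together with compound 3 (the limit of < 0.017 h in this assay, at which 2 of the 3 values shown sit). The step of an at least 47-fold lower number from compound 1 to compound 2 (1.67 log units; beyond the scatter) and the step of an at least 47-fold lower number from compound 1 to compound 3 (1.67 log units; beyond the scatter) were both large, while the step that the two limits leave unreadable from compound 2 to compound 3 cannot be read.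

Compound 4, `FC(F)(F)c1cc(C2CO2)cc(C(F)(F)F)c1`, differs from compound 2 by oxiran-2-yl in place of vinylsulfonyl on an aromatic carbon. Going by the values given here, no measured step bears on an oxiran-2-yl group, and the starting point is a limit, so the size of the change can only be guessed. Compound 4 is expected to give 30 h in this assay, within 3 h to 150 h. The expected step is therefore an at least 1700-fold higher number from compound 2 to compound 4 (3.24 log units; beyond the scatter).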

Compound 4, half-life: > 50 h
Compound 4: only a limit was reported; the forecaster's own chance of this, stated with the estimate: 20%; at least 1.6-fold (0.22 log units) between middle value and limit.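

Set on an aromatic carbon meta to two trifluoromethyl groups, oxiran-2-yl lifts the half-life in this assay well clear of the floor shared by the vinylsulfonyl and (bromomethyl)carbonyl groups, with an at least 2900-fold higher number from compound 2 to compound 4 (3.46 log units; beyond the scatter) and an at least 2900-fold higher number from compound 3 to compound 4 (3.46 log units; beyond the scatter). Going by these compounds alone, it also passes the one earlier compound with a readable half-life, with an at least 62-fold higher number from compound 1 to compound 4 (1.79 log units; beyond the scatter), so (vinylcarbonyl)amino no longer marks the top of what this position allows. For compound 4 the value > 50 h is a limit of the assay, not a number.

On these data alone, the true half-life of compound 4 therefore stays open, and the step from compound 2 to compound 3, with both at a limit, cannot be read. Also open, as far as these compounds go, is whether an aziridine ring or an amine on this carbon would last as long as oxiran-2-yl.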